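Series notes: side-chain variants on the shared core

The source may report more compounds than this note shows. Statements on the series, on what has been measured and on what is new or still open speak of the compounds shown alone.

Measured so far:
compound 1 `O=C1O/C(=C\Cn2cc(-c3ccc(Br)cc3)nn2)C(OCc2ccccc2)=C1OCc1ccccc1` — > 100000 nM
compound 2 `O=C1O[C@H]([C@@H](O)Cn2cc(-c3cc(C(F)(F)F)cc(C(F)(F)F)c3)nn2)C(OCc2ccccc2)=C1OCc1ccccc1` — 80700 nM
compound 3 `CCCCc1cn(C[C@H](O)[C@H]2OC(=O)C(OCc3ccccc3)=C2OCc2ccccc2)nn1` — 26300 nM

In an ADME assay on HFF cells (Homo sapiens) for cytotoxicity, read by MTT assay, with a stated time of 72 h (a higher number here means a weaker inhibitor, a lower number a stronger inhibitor), compound 1 gives > 100000 nM, which is a limit of the assay and not a number. In this assay compound 2 gives 80700 nM and compound 3 gives 26300 nM. Among the measured compounds shown here, compound 3 therefore holds the lowest of the two numbers; the nearest number, that of compound 2, lies beyond the scatter above it, and the one further value is a limit.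

Compound 4 `O=C1O[C@H]([C@@H](O)Cn2cc(CCCCl)nn2)C(OCc2ccccc2)=C1OCc1ccccc1` has not yet been measured in this assay. It differs from compound 3 by chloro in place of methyl on a saturated chain carbon, three bonds along the chain from an aromatic carbon. For the measured compounds named here, no measured pair carries a change of this kind, so there is nothing to set the size of the step against. The step from compound 3 to compound 4 is expected to stay within the scatter, with no direction favoured: a 1.1-fold lower number from compound 3 to compound 4 (0.02 log units; within the scatter). Compound 4 is accordingly estimated at 25000 nM, with a range from 8000 nM to 80000 nM.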

Compound 4, half-maximal inhibitory concentration: 27100 nM
Estimate against measurement, compound 4: 1.1-fold (0.04 log units) below; the range from low to high includes it.
By their numbers in this assay, from the lowest: compounds 3 and 4 (each within the scatter of the next); then compound 2. At a limit, above all of these: compound 1.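

In this assay, the series now has its first step between compounds that differ in one place (a 1.0-fold higher number from compound 3 to compound 4 (0.01 log units; within the scatter)). Among the compounds shown here, on a saturated chain carbon, three bonds along the chain from an aromatic carbon, chloro in place of methyl (butyl to 3-chloropropyl) therefore leaves the two numbers within the scatter of each other, which compound 1 and compound 2 could not show, as no single-change step links either of them to compound 3. Nothing measured here bears on why the two numbers agree.

On these data alone, it remains open whether an amine, a carboxylic acid or a longer chain at this end of the side chain would also stay within the scatter. How far the number depends on the chain end rather than on the rest of the side chain is also unsettled.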